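Shortening the Chain of an Inactive Compound

The source may report more compounds than this note shows. Statements on the series, on what has been measured and on what is new or still open speak of the compounds shown alone.

Compound 2 `CCCCCCCCCCCCCCCCCC(=O)Nc1nnc(S[C@@H]2O[C@H](CO)[C@H](O)[C@H](O)[C@H]2O)s1` offers no number to start from: in a functional assay on DU-145 cells (Homo sapiens) for cytotoxicity, read by MTT assay, with a stated time of 24 h (on this read-out higher numbers stand for weaker inhibition and lower numbers for stronger inhibition), compound 2 is reported as "not active" (no number reported). Two relatives do give numbers in this assay, with compound 1 `CCCCCCCCCCCCCC(=O)Nc1nnc(S[C@@H]2O[C@H](COC(C)=O)[C@H](OC(C)=O)[C@H](OC(C)=O)[C@H]2OC(C)=O)s1` at 34700 nM and compound 3 `CCCCCCCC/C=C\CCCCCCCC(=O)Nc1nnc(S[C@@H]2O[C@H](COC(C)=O)[C@H](OC(C)=O)[C@H](OC(C)=O)[C@H]2OC(C)=O)s1` at 42000 nM.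

Compound 4 `CCCCCCCC(=O)Nc1nnc(S[C@@H]2O[C@H](CO)[C@H](O)[C@H](O)[C@H]2O)s1` differs from compound 2 in its chain, with hydrogen in place of decyl on a saturated chain carbon, seven bonds along the chain from a carbonyl carbon. Among the compounds with values here, only one measured step bears on this kind of change: a 1.2-fold higher number from compound 1 to compound 3 (0.08 log units; within the scatter). That step also alters the chain at the same place, and it stays within the scatter, though it joins a different pair of compounds. Within the data shown here, no measured step starts from compound 2, so no step size can be carried over directly. The expectation in this assay is therefore no step beyond the scatter, with compound 4 staying close to compound 2, and a report without any number is quite possible. Should a number appear, compound 4 is estimated at 100000 nM, with an expected range from 40000 nM to 300000 nM.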

Compound 4, half-maximal inhibitory concentration: "not active" (no number reported)
For compound 4 the study gives words and no number, and the estimate cannot be compared.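

Compound 2 and compound 4 are both reported as "not active" in this assay, and no step can be read between them. No measurement shown offers an explanation for this result. The compounds shown leave open whether the change from decyl to hydrogen alters activity at all.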